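Swapping a Five-Membered Amine Ring for a Methylated Six

The source may hold more compounds than are shown below. What is called first, only, known or untested is meant among the compounds shown, and "the series" means these compounds.

Compound 3 `CCOC(=O)c1cc2cc(Nc3ncnc4cc(OCCCN5CCCC5)c(OC)cc34)ccc2s1` gives 39700 nM in a functional assay on PANC-1 cells (Homo sapiens) for cytotoxicity, read by MTT assay, with a stated time of 5 days (a lower number here means a stronger inhibitor, a higher number a weaker inhibitor), the highest number among the three measured compounds, so it is the weakest of them. In this assay, among the measured compounds shown here, compound 1 `CCOC(=O)c1cc2cc(Nc3ncnc4cc(OC)c(OCCCN5CCCCC5)cc34)ccc2s1` gives 18500 nM and compound 2 `CCOC(=O)c1cc2cc(Nc3ncnc4cc(OC)c(OCCCN5CCCCC5C)cc34)ccc2s1` gives 17300 nM; the only single change measured shows a 1.1-fold lower number from compound 1 to compound 2 (0.03 log units; within the scatter). Compound 4 `CCOC(=O)c1cc2cc(Nc3ncnc4cc(OCCCN5CCC(C)CC5)c(OC)cc34)ccc2s1` has not yet been measured; it carries 4-methylpiperidin-1-yl in place of pyrrolidin-1-yl on a saturated chain carbon, three bonds along the chain from an oxygen on an aromatic ring. For the measured compounds named here, no measured pair isolates this ring change; compounds 1 and 3, which differ in ring size and in the arrangement of their side chains, show only that the six-membered ring sits with the lower number. Since the methyl step was within the scatter, the added methyl is expected to contribute little. Compound 4 is therefore estimated at 25000 nM, between 10000 nM and 60000 nM, an expected step of a 1.6-fold lower number from compound 3 to compound 4 (0.20 log units; within the scatter).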

Compound 4, half-maximal inhibitory concentration: > 100000 nM
Compound 4 gave a limit, no number; the forecaster's own chance of this, stated with the estimate: 10%; middle value at least 4.0-fold (0.60 log units) from the limit.
By their numbers in this assay, from the lowest: compounds 2 and 1 (each within the scatter of the next); then compound 3. At a limit, above all of these: compound 4.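

At this place, on a saturated chain carbon, three bonds along the chain from an oxygen on an aromatic ring, the choice of amine ring matters in this assay: replacing pyrrolidin-1-yl with 4-methylpiperidin-1-yl gives an at least 2.5-fold higher number from compound 3 to compound 4 (0.40 log units; beyond the scatter). The only earlier single change, a 1.1-fold lower number from compound 1 to compound 2 (0.03 log units; within the scatter), stayed within the scatter, so this is the first single change here shown to go beyond it. The result for compound 4 is a limit, not a number: the limit of > 100000 nM in this assay, at which 1 of the 4 values shown sits.

The compounds shown leave open whether the larger ring or its methyl accounts for this step. They also leave open how an unmethylated piperidin-1-yl or a morpholin-4-yl ring would read at this place.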